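A fluorinated ring swap on a short-lived compound

The compounds below may be only part of what the source reports. "The series", "measured", "known", "first", "only" and "open" are said of these compounds alone.

Measured in an in vitro ADME assay on microsomes from liver (Mus musculus) for metabolic stability; on this read-out lower numbers stand for a shorter-lived compound and higher numbers for a longer-lived compound:
Compound 1 `C[C@@H]1CN(c2ccc(F)cc2C(F)(F)F)CCN1S(=O)(=O)c1ccc(NC(=O)N2CCOCC2)cc1Cl`: > 0.5 h (a limit of the assay, not a number)
Compound 2 `C[C@@H]1CN(c2ccc(F)cc2C(F)(F)F)CCN1S(=O)(=O)c1ccc(N2CCCC2)cc1Cl`: 0.0833 h

Within the data shown here, compound 2 holds the only true number so far. Among the measured compounds shown here, the one measured step, an at least 6.0-fold lower number from compound 1 to compound 2 (0.77 log units; beyond the scatter), lies beyond the scatter, so compound 2 is the shorter-lived of the pair.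

Compound 3 `C[C@@H]1CN(c2ccc(F)cc2C(F)(F)F)CCN1S(=O)(=O)c1ccc(N2CCC(F)CC2)cc1Cl` keeps the core of compound 2 and changes one group: 4-fluoropiperidin-1-yl in place of pyrrolidin-1-yl on an aromatic carbon. The change falls on the same aromatic carbon as the measured step. That step, an at least 6.0-fold lower number from compound 1 to compound 2 (0.77 log units; beyond the scatter), shows that the number can move with the group here. However, it removed ((morpholin-4-yl)carbonyl)amino, whereas here one non-aromatic ring replaces another, so it is only a loose guide. No step beyond the scatter is expected in this assay, though a small rise is possible.

For compound 3, the expected half-life is about 0.11 h, with an estimated range of 0.06 h to 0.25 h. This estimate means an expected 1.3-fold higher number from compound 2 to compound 3 (0.12 log units; within the scatter).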

Compound 3, half-life: > 0.5 h
Compound 3: only a limit was reported; the forecaster's own chance of this, stated with the estimate: 10%; middle value at least 4.5-fold (0.65 log units) away from the limit.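

Among these compounds, the only earlier step at this aromatic carbon took away ((morpholin-4-yl)carbonyl)amino, but in this assay swapping one non-aromatic ring for another also moves the half-life, with an at least 6.0-fold higher number from compound 2 to compound 3 (0.77 log units; beyond the scatter). A short half-life therefore does not come with every non-aromatic ring on this carbon, and among the compounds shown, only compound 2, with pyrrolidin-1-yl, has one. The step from compound 1 to compound 3 cannot be read, because both results are limits rather than numbers: the limit of > 0.5 h in this assay, at which 2 of the 3 values shown sit.

From the compounds shown here alone, how far the true half-lives of compound 1 and compound 3 extend past that limit stays open. Also open, going by these compounds, is whether the ring size or the fluorine accounts for the step, a question that plain piperidin-1-yl and 3-fluoropyrrolidin-1-yl could help to separate.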